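From Dimethoxyphenyl to Naphthyl on the Unmethylated Sulfonamide

This account rests on a few compounds, and the source may have more. Where it says the series, first, only, none or still open, it means among the compounds named here.

Compound 1 `COc1ccc(OC)c(COc2cc(NC(=O)c3ccc(OC)c(OC)c3)ccc2N(C)S(C)(=O)=O)c1` is the reference point of this small set: in a functional assay on SK-BR-3 cells (Homo sapiens) for antiproliferative activity, read by MTT assay, with a stated time of 48 h (a lower number here means a stronger inhibitor, a higher number a weaker inhibitor), compound 1 gives 2.61 nM. Two single changes to it have been measured. Compound 2 `COc1ccc(OC)c(COc2cc(NC(=O)c3ccc4ccccc4c3)ccc2N(C)S(C)(=O)=O)c1` carries naphthalen-2-yl in place of 3,4-dimethoxyphenyl on the carbonyl carbon; in this assay compound 2 gives 16.6 nM, so that a 6.4-fold higher number from compound 1 to compound 2 (0.80 log units; beyond the scatter). Compound 3 `COc1ccc(OC)c(COc2cc(NC(=O)c3ccc(OC)c(OC)c3)ccc2NS(C)(=O)=O)c1` keeps the 3,4-dimethoxyphenyl group but has hydrogen instead of methyl on the sulfonamide nitrogen; in this assay compound 3 gives 11 nM, so that a 4.2-fold higher number from compound 1 to compound 3 (0.62 log units; beyond the scatter). Among the three numbers compound 3 thus stands second highest, beyond the scatter from compound 1 and within the scatter of compound 2.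

Compound 4 `COc1ccc(OC)c(COc2cc(NC(=O)c3ccc4ccccc4c3)ccc2NS(C)(=O)=O)c1` has not been measured. It differs from compound 3 in one place: naphthalen-2-yl in place of 3,4-dimethoxyphenyl on a carbonyl carbon. Among the compounds with values here, only one measured step carries the same exchange, the one from compound 1 to compound 2, and there the number rose by a modest amount beyond the scatter. With no contrary evidence, a rise of similar size is expected on going from compound 3 to compound 4, that is, a 6.4-fold higher number from compound 3 to compound 4 (0.80 log units; beyond the scatter). In this assay compound 4 is therefore estimated at 70 nM, with a likely range from 25 nM to 200 nM.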

Compound 4, half-maximal inhibitory concentration: 13.3 nM
The estimate for compound 4 lay 5.3-fold (0.72 log units) above the measured number; the measured number lies below the stated range.
By their numbers in this assay, from the lowest: compound 1; then compounds 3, 4 and 2 (each within the scatter of the next).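

On the core with hydrogen on the sulfonamide nitrogen, naphthalen-2-yl in place of 3,4-dimethoxyphenyl on the carbonyl carbon gives in this assay only a 1.2-fold higher number from compound 3 to compound 4 (0.08 log units; within the scatter), so this exchange has no fixed size and what it does depends on what the sulfonamide nitrogen carries: the same change on two cores in this assay, a 6.4-fold higher number (0.80 log units; beyond the scatter) from compound 1 to compound 2 and a 1.2-fold higher number (0.08 log units; within the scatter) from compound 3 to compound 4, 5.3-fold (0.72 log units) apart, beyond the scatter of two such steps. Read the other way, hydrogen in place of methyl on the sulfonamide nitrogen shows up with naphthalen-2-yl as a 1.2-fold lower number from compound 2 to compound 4 (0.10 log units; within the scatter), so that change also depends on the group on the carbonyl carbon: the same change on two cores in this assay, a 4.2-fold higher number (0.62 log units; beyond the scatter) from compound 1 to compound 3 and a 1.2-fold lower number (0.10 log units; within the scatter) from compound 2 to compound 4, 5.3-fold (0.72 log units) apart, beyond the scatter of two such steps. Either single change away from compound 1 raises the number, but making the second on top of the first adds nothing beyond the scatter, so the two changes do not add up.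

From the compounds shown here alone, whether this dependence holds for a longer chain such as ethyl on the sulfonamide nitrogen, or for a plain phenyl or a pyridine ring on the carbonyl carbon, stays open. Why the two places depend on each other also stays open, as these numbers describe the outcome in these cells and not how it comes about.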